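The source may hold more compounds than are shown below. What is called first, only, known or untested is meant among the compounds shown, and "the series" means these compounds.

Compound 1 `COc1ccccc1-c1ncnn1-c1cc(OC)c(OC)c(OC)c1`: > 10000 nM in a functional assay on HeLa cells (Homo sapiens) for antiproliferative activity, read by MTT assay, with a stated time of 72 h (on this read-out higher numbers stand for weaker inhibition and lower numbers for stronger inhibition), a limit of the assay rather than a number.
Compound 2 `COc1cc(-c2ncnn2-c2cccc(N)c2)cc(OC)c1OC`: > 10000 nM in this assay, also a limit.

Both measured compounds share a core that carries two aryl groups. In this assay compound 2 gives only a limit, > 10000 nM, and no number. In this assay compound 1 likewise stops at a limit, > 10000 nM. Within the data shown here, compound 2 therefore stands at the limit of > 10000 nM in this assay, at which 2 of the 2 values shown sit, and no measured step between these two compounds exists, so nothing can be said of what any swap of groups does on this read-out.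

Compound 3 `COc1ccc(-n2ncnc2-c2cc(OC)c(OC)c(OC)c2)cc1` is not yet measured. It differs from compound 2 in one place: 4-methoxyphenyl in place of 3-aminophenyl on an aromatic nitrogen. With both reference points sitting at the limit, the step in this assay from compound 2 to compound 3 is expected to be none beyond the scatter, and compound 3 is expected to be reported again only as a limit rather than as a number: the estimated step is a step that the limit leaves unreadable from compound 2 to compound 3. Compound 3 is expected to give 15000 nM, within a range from 5000 nM to 50000 nM.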

Compound 3, half-maximal inhibitory concentration: > 10000 nM
Compound 3: only a limit was reported; the forecaster's own chance of this, stated with the estimate: 75%; the middle value does not contradict the limit.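

Among these compounds, compound 3, like compound 2, is reported only as a limit in this assay, so no step between compound 2 and compound 3 can be read: the limit of > 10000 nM in this assay, at which 3 of the 3 values shown sit. The compounds shown leave open whether any swap of groups on the shared core would give a measurable number on this read-out.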